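Swapping methyl for 4-methoxybenzyl in compound 2

The source may report more compounds than this note shows. Statements on the series, on what has been measured and on what is new or still open speak of the compounds shown alone.

In a functional assay on cells (Cancer cell lines, Homo sapiens) for cytotoxicity, with a stated time of 48 h (on this read-out higher numbers stand for weaker inhibition of growth and lower numbers for stronger inhibition of growth), compound 1 (`COc1cc(/C=C2/C(=O)N(C)c3ccc(O)cc32)cc(OC)c1OC`) gives 22400 nM and compound 2 (`COc1ccc2c(c1)/C(=C\c1cc(OC)c(OC)c(OC)c1)C(=O)N2C`) gives 24000 nM, so the two lie within the scatter of each other. Compound 3 (`COc1ccc(CN2C(=O)/C(=C/c3cc(OC)c(OC)c(OC)c3)c3cc(OC)ccc32)cc1`) keeps the core of compound 2 and differs at one place: 4-methoxyphenyl in place of hydrogen on a saturated chain carbon bound to an amide-type nitrogen in a ring. In simpler words, methyl becomes 4-methoxybenzyl. Within the data shown here, the only measured step, a 1.1-fold higher number from compound 1 to compound 2 (0.03 log units; within the scatter), lies at another place on the molecule and offers weak guidance, so no change beyond the scatter is expected. The expected step is a 1.5-fold lower number from compound 2 to compound 3 (0.18 log units; within the scatter). Compound 3 is estimated at 16000 nM, with an expected range of 5000 nM to 50000 nM.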

Compound 3, concentration for total growth inhibition: 8900 nM
Estimate against measurement, compound 3: 1.8-fold (0.25 log units) above; low and high end bracket the measured number.
By their numbers in this assay, from the lowest: compound 3; then compounds 1 and 2 (each within the scatter of the next).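

On the amide-type nitrogen in the ring, the small methyl can give way to the much larger 4-methoxybenzyl with a gain rather than a loss: in this assay, this change gives a 2.7-fold lower number from compound 2 to compound 3 (0.43 log units; beyond the scatter). The step is modest, but unlike the earlier change elsewhere on the molecule, it lies beyond the scatter.

As far as these compounds go, whether a plain benzyl, a longer alkyl chain or a chain ending in an amine would do the same remains open. No supporting data show why the number fell.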